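The source may hold more compounds than are shown below. What is called first, only, known or untested is meant among the compounds shown, and "the series" means these compounds.

Three compounds share one core and differ only in the aryl group carried on an aromatic nitrogen. In an assay on CHO-K1 cells for antagonist activity at transient receptor potential cation channel subfamily V member 1 (Homo sapiens), read by FLIPR and calcium flux, with a stated time of 6 min (a higher number here means a weaker inhibitor, a lower number a stronger inhibitor), compound 3 `CC(C)(C)c1cc(CNC(=O)Nc2cccc3[nH]ncc23)n(-c2ccc(F)c(F)c2)n1` gives 0.5 nM, the lowest number of the three; compound 1 `CC(C)(C)c1cc(CNC(=O)Nc2cccc3[nH]ncc23)n(-c2cccc(Cl)c2)n1` gives 0.6 nM, and the two sit within the scatter, as a 1.2-fold lower number from compound 1 to compound 3 (0.08 log units; within the scatter) shows. Compound 2 `CC(C)(C)c1ccc(-n2nc(C(C)(C)C)cc2CNC(=O)Nc2cccc3[nH]ncc23)cc1` gives 40 nM; the steps of a 67-fold higher number from compound 1 to compound 2 (1.82 log units; beyond the scatter) and an 80-fold lower number from compound 2 to compound 3 (1.90 log units; beyond the scatter) are both large. Compound 4 `Cn1ncc2c(NC(=O)NCc3cc(C(C)(C)C)nn3-c3ccc(F)c(F)c3)cccc21` keeps the aryl group of compound 3 and differs elsewhere: methyl in place of hydrogen on an aromatic nitrogen. Within the data shown here, none of the measured steps touches this position, so they offer no guide to the size or direction of the change. For compound 4 a weaker result is expected, a 10-fold higher number from compound 3 to compound 4 (1.00 log units; beyond the scatter), with 5 nM estimated and a wide range from 0.5 nM to 50 nM.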

Compound 4, inhibition constant: 1 nM
Estimate against measurement, compound 4: 5.0-fold (0.70 log units) above; low and high end bracket the measured number.
By their numbers in this assay, from the lowest: compounds 3, 1 and 4 (each within the scatter of the next); then compound 2.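

Placing methyl on this aromatic nitrogen, which turns 1H-indazol-4-yl into 1-methyl-1H-indazol-4-yl, gives a 2.0-fold higher number from compound 3 to compound 4 (0.30 log units; within the scatter) in this assay and so stays within the scatter. The hydrogen on this nitrogen can therefore be replaced without a clear loss, at least alongside the 3,4-difluorophenyl group of compound 3. Nothing measured here explains this result. Still open, from the compounds shown here alone, is whether an ethyl group, a longer chain or a chain ending in an amine would fare as well on this nitrogen, and whether methyl behaves the same alongside the 3-chlorophenyl group of compound 1.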